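The source may report more compounds than this note shows. Statements on the series, on what has been measured and on what is new or still open speak of the compounds shown alone.

Compound 1 `CCN(CC)CCNC(=O)c1ccc(C(CC)(CC)c2ccc(OCCC(O)(CC)CC)c(C)c2)n1CC`: 2.3 nM
Compound 2 `C=CCN(C)C(=O)c1ccc(C(CC)(CC)c2ccc(OCCC(O)(CC)CC)c(C)c2)n1CC`: > 10000 nM

In an assay on cells for agonist activity at vitamin D3 receptor (Homo sapiens), with a stated time of 96 h (a lower number here means that less compound is needed, a higher number that more compound is needed for the effect), compound 2 stands only at a limit of the assay, > 10000 nM, so no exact number is known for it. Compound 3 `C#CCCOC(=O)c1ccc(C(CC)(CC)c2ccc(OCCC(O)(CC)CC)c(C)c2)n1CC` differs from it by (but-3-yn-1-yl)oxy in place of allyl(methyl)amino on a carbonyl carbon. For the measured compounds named here, the one measured step, an at least 4300-fold higher number from compound 1 to compound 2 (3.63 log units; beyond the scatter), was large and arrived at the limit (the limit of > 10000 nM in this assay, at which 1 of the 2 values shown sits); compound 3 likewise lacks the (2-(diethylamino)ethyl)amino group that compound 1 carries, and a similar outcome seems likely. Compound 3 is therefore estimated at 10000 nM, with a range of 1500 nM to 50000 nM. The expected step of a number no higher from compound 2 to compound 3 (the limit leaves the size open) is none beyond the scatter.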

Compound 3, half-maximal effective concentration: 6030 nM
Beside the measured number, compound 3's estimate is 1.7-fold (0.22 log units) above it; low and high end bracket the measured number.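

Compound 2 has only a limit, not an exact number: the limit of > 10000 nM in this assay, at which 1 of the 3 values shown sits. Compound 3 gives an exact number on this carbonyl carbon, but with (but-3-yn-1-yl)oxy in place of allyl(methyl)amino the change is an at least 1.6-fold lower number from compound 2 to compound 3 (0.21 log units; that floor lies within the scatter), so no real difference between the two can be claimed. Without the (2-(diethylamino)ethyl)amino group, the size of the loss can now be stated: a 2600-fold higher number from compound 1 to compound 3 (3.42 log units; beyond the scatter). Still open, on these data alone, is which part of that group matters, and whether a shorter chain ending in a dimethylamino group would keep the low number. As far as these compounds go, a carboxylic acid at this place also remains open.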